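A few compounds are considered here, and "the series" means these few. Any claim that something is new, unique, unknown or untested is made for them only; others in the source may bear on it.

The compounds measured in a functional assay on the whole organism (integument) for inhibition, with Chilo suppressalis as the target, read by scintillation counting, with a stated time of 72 h (on this read-out lower numbers stand for stronger inhibition and higher numbers for weaker inhibition), are:
Compound 1 `O=C(Nc1nnc(-c2ccc(Cl)cc2)s1)c1ccccc1I` gives > 5010 nM, which is a limit of the assay and not a number.
Compound 2 `Cc1ccccc1C(=O)Nc1nnc(-c2ccc(Cl)cc2)s1` gives 158 nM.
Compound 3 `COc1cccc(OC)c1C(=O)Nc1nnc(-c2ccc(C)cc2)s1` gives 1230 nM.

Among the two numbers shown, compound 3 stands highest; its nearest neighbour is compound 2, which sits at a lower number, and that gap lies beyond the scatter. Compound 1 contributes only a limit, (the limit of > 5010 nM in this assay, at which 1 of the 3 values shown sits), and cannot be ranked against the others. Within the data shown here, the single measured step within this set, an at least 31-fold lower number from compound 1 to compound 2 (1.50 log units; beyond the scatter), is a large one, but it concerns an exchange at a different aromatic carbon of the shared core.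

Compound 4 `COc1cccc(OC)c1C(=O)Nc1nnc(-c2ccc(C(F)(F)F)cc2)s1` differs from compound 3 by trifluoromethyl in place of methyl on an aromatic carbon. Among the measured compounds shown here, no measured step touches this position or this exchange, so nothing here argues for a shift in either direction beyond the scatter. Compound 4 is therefore expected to give about 1200 nM, with a range from 350 nM to 4500 nM. The expected step from compound 3 to compound 4, a 1.0-fold lower number from compound 3 to compound 4 (0.01 log units; within the scatter), is estimated to stay within the scatter.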

Compound 4, half-maximal inhibitory concentration: 49 nM
Estimate against measurement, compound 4: 24-fold (1.39 log units) above; measured number below the stated range.
By their numbers in this assay, from the lowest: compound 4; then compound 2; then compound 3. At a limit, above all of these: compound 1.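

In this assay, the step of a 25-fold lower number from compound 3 to compound 4 (1.40 log units; beyond the scatter) shows that this position, on a six-membered aromatic ring of carbon only and para to a large group, responds strongly to the group it carries. Until now, the only measured step concerned an exchange at a different aromatic carbon, so nothing had shown that trifluoromethyl in place of methyl could move the number by this much. Nothing given here accounts for the size of this step.

As far as these compounds go, only methyl and trifluoromethyl can be compared directly at this position, so it remains open how a nitrile, an amine or a carboxylic acid there would read out. Among these compounds, it also remains open whether the same exchange would give a step of similar size on a shared core carrying a different group in place of the one found in compound 3.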